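The source may report more compounds than this note shows. Statements on the series, on what has been measured and on what is new or still open speak of the compounds shown alone.

Measured so far in a functional assay for antagonist activity at transient receptor potential cation channel subfamily V member 1 (Homo sapiens), read by FLIPR and calcium flux; on this read-out higher numbers stand for weaker inhibition and lower numbers for stronger inhibition:
compound 1 `O=C1COc2ccc(NC(=O)C3CCN(c4cccc(Cl)c4)CC3)cc2N1` gives 190 nM;
compound 2 `O=C1COc2ccc(NC(=O)C3CCN(c4cc(F)c(F)c(F)c4)CC3)cc2N1` gives 59 nM.

Of these two numbers, compound 2 holds the lower one, and the gap to compound 1 lies beyond the scatter. Going by the values given here, the one measured step, a 3.2-fold lower number from compound 1 to compound 2 (0.51 log units; beyond the scatter), shows that the aryl group on the ring nitrogen moves the read-out by a modest amount. Compound 3 `O=C1COc2ccc(NC(=O)C3CCN(c4ccccc4C(F)(F)F)CC3)cc2N1` is now to be measured in this assay. It differs from compound 2 in one place: 2-(trifluoromethyl)phenyl in place of 3,4,5-trifluorophenyl on an amine nitrogen in a ring. The measured step changed the ring substituents at a different pattern than this one, so it bears on the new step only in showing that this position is sensitive. An account of compound 3 thus expects a step of about a 2.5-fold higher number from compound 2 to compound 3 (0.41 log units; beyond the scatter), with a wide spread. Compound 3 is estimated at 150 nM, within 40 nM to 600 nM.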

Compound 3, half-maximal inhibitory concentration: 380 nM
The estimate for compound 3 lay 2.5-fold (0.40 log units) below the measured number; low and high end bracket the measured number.
By their numbers in this assay, from the lowest: compound 2; then compounds 1 and 3 (each within the scatter of the next).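

In this assay, putting 2-(trifluoromethyl)phenyl in place of 3,4,5-trifluorophenyl on the ring nitrogen gives a 6.4-fold higher number from compound 2 to compound 3 (0.81 log units; beyond the scatter), so the number at this position can go up as well as down with the choice of aryl group. Compound 3 and compound 1 stand within the scatter of each other, at a 2.0-fold higher number from compound 1 to compound 3 (0.30 log units; within the scatter), which shows that of the three aryl groups only the 3,4,5-trifluorophenyl of compound 2 stands apart on this read-out. Nothing at hand says why these aryl groups read as they do.

On these data alone, whether the read-out follows the kind of substituent on the phenyl ring or the place where it stands remains open: compound 2 and compound 3 differ in both. As far as these compounds go, how a nitrile, a methoxy group or a plain phenyl would read on this ring nitrogen is also open.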